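The source may report more compounds than this note shows. Statements on the series, on what has been measured and on what is new or still open speak of the compounds shown alone.

Three analogues sharing one core have been measured in a functional assay on MCF7 cells (Homo sapiens) for antiproliferative activity; on this read-out lower numbers stand for stronger inhibition and higher numbers for weaker inhibition. Compound 1 `C=CCc1cc(C(=O)Nc2cc3ccc(OC4CCN(C)CC4)c(C)c3oc2=O)ccc1OC(C)=O` gives 2000 nM in this assay. Compound 2 `CC(C)=CCc1cccc(C(=O)Nc2cc3ccc(OC4CCN(C)CC4)c(C)c3oc2=O)c1` gives 2100 nM. Compound 3 `CC(=O)Oc1ccc(C(=O)Nc2cc3ccc(OC4CCN(C)CC4)c(C)c3oc2=O)cc1Cl` gives 1610 nM. Compound 3 has the lowest of the three numbers, but its steps from the other two are small: a 1.2-fold lower number from compound 1 to compound 3 (0.09 log units; within the scatter) and a 1.3-fold lower number from compound 2 to compound 3 (0.12 log units; within the scatter), so the three compounds sit within the scatter of one another and no order among them can be claimed.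

Compound 4 `Cc1c(OC2CCN(C)CC2)ccc2cc(NC(=O)c3ccc(O)c(Cl)c3)c(=O)oc12` is the next compound and has not yet been measured in this assay. It differs from compound 3 in one place: hydrogen in place of acetyl on an oxygen on an aromatic ring. Among the compounds with values here, none of the measured steps touches this oxygen; both known steps alter the aromatic ring that carries it, and both stayed within the scatter. Within the data shown here, there is therefore no measured step that speaks directly to the effect of exchanging acetyl for hydrogen here, and the record so far shows a series that is rather flat across three different substitution patterns on that ring.

On that basis the expectation for compound 4 in this assay is a step of a 1.1-fold lower number from compound 3 to compound 4 (0.03 log units; within the scatter), that is, no change beyond the scatter, with compound 4 estimated at 1500 nM, in a range from 600 nM to 4000 nM.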

Compound 4, half-maximal inhibitory concentration: 1480 nM
The estimate for compound 4 lay 1.0-fold (0.01 log units) above the measured number, and the stated range covers the measured number.
By their numbers in this assay, from the lowest: compounds 4, 3, 1 and 2 (each within the scatter of the next).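

In this assay, within the data shown here, the exchange of acetoxy for hydroxy gives a 1.1-fold lower number from compound 3 to compound 4 (0.04 log units; within the scatter) and so stays within the scatter; this is the first step to touch the oxygen on the aromatic ring itself, and it shows that, with chloro kept on the ring, the acetyl and a bare hydrogen on that oxygen cannot be told apart on this read-out. Among these compounds, the wider exchange, 3-chloro-4-hydroxyphenyl in place of 3-(3-methylbut-2-en-1-yl)phenyl on the carbonyl carbon, gives a 1.4-fold lower number from compound 2 to compound 4 (0.15 log units; within the scatter) and also stays within the scatter, so the free hydroxy form adds no step beyond the scatter to those already read among the earlier compounds. Nothing is available that would explain this result or tie it to any property of the groups.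

The compounds shown leave open whether a methyl ether, a longer acyl chain such as butanoyl, or a carboxylic acid or an amine in place of the hydroxy would move the number beyond the scatter. They also leave open whether the hydroxy would read the same with allyl in place of chloro on the ring.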